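The source may hold more compounds than are shown below. What is called first, only, known or untested is meant among the compounds shown, and "the series" means these compounds.

Compound 1 `Cc1nc(C(=O)c2ccc(C)s2)c2sccc2n1`: in a functional assay on CHO-K1 cells for antagonist activity at adenosine receptor A2b (Homo sapiens), read by FLIPR and calcium flux (a higher number here means a weaker inhibitor, a lower number a stronger inhibitor), compound 1 gives > 10000 nM, which is a limit of the assay rather than a number.
Compound 2 `CCc1nc(C(=O)c2ccc(C)s2)c2sccc2n1`: compound 2 gives 3670 nM.
Compound 3 `Cc1ccc(C(=O)c2nc(NCc3ccccc3)nc3ccsc23)s1`: compound 3 gives 5580 nM.

Compound 3 and compound 2 sit close together, since a 1.5-fold higher number from compound 2 to compound 3 (0.18 log units; within the scatter); compound 1 offers only a limit, so an at least 1.7-fold lower number from compound 1 to compound 3 (0.25 log units; that floor lies within the scatter) has a floor that is itself within the scatter. Compound 4 `Cc1ccc(C(=O)c2nc(NC(=O)c3cccnc3)nc3ccsc23)s1` changes compound 3 by (pyridin-3-yl)carbonyl in place of benzyl on a nitrogen on an aromatic ring. Among the compounds with values here, no measured step touches the (pyridin-3-yl)carbonyl group; the two steps that reach compound 3 both concern the benzylamino group and show little movement. The expectation is therefore a step near a 1.1-fold higher number from compound 3 to compound 4 (0.03 log units; within the scatter), with no clear direction beyond the scatter. Compound 4 is estimated at 6000 nM, within 2000 nM to 20000 nM.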

Compound 4, half-maximal inhibitory concentration: 287 nM
Estimate against measurement, compound 4: 21-fold (1.32 log units) above; the measured number lies below the stated range.
By their numbers in this assay, from the lowest: compound 4; then compounds 2 and 3 (each within the scatter of the next). At a limit, above all of these: compound 1.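

Within the data shown here, at the nitrogen on the aromatic ring, the choice of group matters far more than the earlier compounds could show: in this assay, (pyridin-3-yl)carbonyl in place of benzyl gives a 19-fold lower number from compound 3 to compound 4 (1.29 log units; beyond the scatter). The earlier steps shown here that reach the benzylamino group gave no sign of a change this large. No measurement shown gives a cause for this step.

On these data alone, the carbonyl and the pyridine ring enter together, so which of them carries the step stays open. A benzoyl or acetyl group on the same nitrogen would begin to separate the two.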